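Morpholin-4-yl for Piperidin-1-yl: One Change, Two Cores

This account rests on a few compounds, and the source may have more. Where it says the series, first, only, none or still open, it means among the compounds named here.

Compound 1 `O=C(CSC(=S)N1CCCCC1)Nc1cccc(NC(=O)c2ccccn2)c1` and compound 2 `O=C(CSC(=S)N1CCOCC1)Nc1cccc(NC(=O)c2ccccn2)c1` share a core and differ at one point only: morpholin-4-yl in place of piperidin-1-yl on a thiocarbonyl carbon. In a functional assay on A549 cells (Homo sapiens) for antiproliferative activity, read by MTT assay, with a stated time of 48 h (a higher number here means a weaker inhibitor, a lower number a stronger inhibitor), compound 1 gives 320 nM, while compound 2 gives 50 nM, a step of a 6.4-fold lower number from compound 1 to compound 2 (0.81 log units; beyond the scatter). Compound 3 `O=C(CCSC(=S)N1CCCCC1)Nc1cccc(NC(=O)c2ccccn2)c1` carries the piperidin-1-yl of compound 1 on a different core; the difference between the two cores is not broken down here. In this assay compound 3 gives 4120 nM, the highest of the three numbers. Compound 4 `O=C(CCSC(=S)N1CCOCC1)Nc1cccc(NC(=O)c2ccccn2)c1` is compound 3 with the same change, (morpholin-4-yl in place of piperidin-1-yl on a thiocarbonyl carbon), on the same place. Because the step of a 6.4-fold lower number from compound 1 to compound 2 (0.81 log units; beyond the scatter) was modest and was seen only once, on another core, a step of similar but uncertain size is expected, a 5.2-fold lower number from compound 3 to compound 4 (0.71 log units; beyond the scatter). Compound 4 is therefore expected near 800 nM, most likely between 250 nM and 2600 nM.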

Compound 4, half-maximal inhibitory concentration: 2420 nM
Beside the measured number, compound 4's estimate is 3.0-fold (0.48 log units) below it, within the range that was stated.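

In this assay, morpholin-4-yl in place of piperidin-1-yl gives a 1.7-fold lower number from compound 3 to compound 4 (0.23 log units; within the scatter), so the step seen on the first core did not carry over at the same size to the second: the same change on two cores in this assay, a 6.4-fold lower number (0.81 log units; beyond the scatter) from compound 1 to compound 2 and a 1.7-fold lower number (0.23 log units; within the scatter) from compound 3 to compound 4, 3.8-fold (0.58 log units) apart, beyond the scatter of two such steps. On the core of compound 3, the change leaves the two numbers within the usual scatter of each other, so a step measured on one core cannot simply be assumed on another in this series. Going by these compounds alone, with only two cores, these data do not show why the steps differ, or how the change would behave on any further core.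

The compounds shown leave open how a piperazin-1-yl group on the thiocarbonyl carbon would compare with morpholin-4-yl. They also leave open what size the step would take on a core with a longer chain.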